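From a hydroxypropyl chain to a hexyl chain

The source may report more compounds than this note shows. Statements on the series, on what has been measured and on what is new or still open speak of the compounds shown alone.

Three compounds share one core. Compound 1 `Fc1ccccc1Cn1nnc2c(NC3CC3)nc(-c3ccccc3)nc21` gives 15000000 nM in an assay on isolated protein for binding affinity to adenosine receptor A1 (Bos taurus); a lower number here means a stronger inhibitor, a higher number a weaker inhibitor. Compound 2 `CCCCNc1nc(-c2ccccc2)nc2c1nnn2Cc1ccccc1F` gives 4300000 nM in this assay, and compound 3 `CC(O)CNc1nc(-c2ccccc2)nc2c1nnn2Cc1ccccc1F` gives 4800000 nM. Compound 3 thus stands second highest of the three numbers, near compound 2 and well below compound 1. Compound 4 `CCCCCCNc1nc(-c2ccccc2)nc2c1nnn2Cc1ccccc1F` differs from compound 3 by pentyl in place of 1-hydroxyethyl on a saturated chain carbon bound to a nitrogen on an aromatic ring. Going by the values given here, the only measured step that bears on this is a 1.1-fold higher number from compound 2 to compound 3 (0.05 log units; within the scatter), which exchanged a plain chain for a hydroxy-bearing one without moving the number beyond the scatter; no measured step lengthens the chain itself. A change within the scatter is therefore expected in this assay, so the step of a 1.4-fold lower number from compound 3 to compound 4 (0.14 log units; within the scatter) is expected. Compound 4 is estimated at 3500000 nM, within 1000000 nM to 12000000 nM.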

Compound 4, inhibition constant: 25000000 nM
Compound 4: the middle estimate sits 7.1-fold (0.85 log units) below what was measured; the measured number lies above the stated range.
By their numbers in this assay, from the lowest: compounds 2 and 3 (each within the scatter of the next); then compounds 1 and 4 (each within the scatter of the next).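

In this assay, the length of a plain chain at this position matters: replacing butyl with hexyl gives a clear rise (a 5.8-fold higher number from compound 2 to compound 4 (0.76 log units; beyond the scatter)), and so does replacing 2-hydroxypropyl with hexyl (a 5.2-fold higher number from compound 3 to compound 4 (0.72 log units; beyond the scatter)). The earlier swap between butyl and 2-hydroxypropyl had shown no such change. The lower numbers that butyl and 2-hydroxypropyl gave relative to cyclopropyl also do not carry over to hexyl (a 1.7-fold higher number from compound 1 to compound 4 (0.22 log units; within the scatter)).

Nothing measured here accounts for the rise. On these data alone, whether an octyl chain climbs further, or whether a hexyl chain ending in a hydroxyl or an amine behaves like plain hexyl, stays open.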